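The source may report more compounds than this note shows. Statements on the series, on what has been measured and on what is new or still open speak of the compounds shown alone.

Working notes on the series. Three compounds on a shared core have numbers in a functional assay on HepG2 cells (Homo sapiens) for cytotoxicity, read by MTT assay, with a stated time of 24 h; a higher number here means a weaker inhibitor, a lower number a stronger inhibitor. Compound 1 `O=C1/C(=C/c2cccnc2)CN(S(=O)(=O)c2ccc(Br)cc2)C/C1=C\c1ccccc1F` gives 8700 nM, compound 2 `O=C1/C(=C/c2cccnc2)CNC/C1=C\c1ccccc1C(F)(F)F` gives 5020 nM and compound 3 `O=C1/C(=C/c2cccnc2)CN(S(=O)(=O)c2ccc(C(F)(F)F)cc2)C/C1=C\c1ccccc1C(F)(F)F` gives 1710 nM. Compound 3 therefore holds the lowest number of the three, and its gaps to compound 2 and to compound 1 both lie beyond the usual scatter.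

The next entry is compound 4 `O=C1/C(=C/c2cccnc2)CN(S(=O)(=O)c2ccc(Br)cc2)C/C1=C\c1ccccc1C(F)(F)F`. It departs from compound 3 in one place: bromo in place of trifluoromethyl on an aromatic carbon, which puts bromo in place of trifluoromethyl on an aromatic carbon, read one bond further out as 4-(trifluoromethyl)phenyl to 4-bromophenyl. Among the measured compounds shown here, no measured pair shows this exchange alone, so the size of the step has no direct precedent. For the measured compounds named here, the only guide is compound 1, which carries the same 4-bromophenyl group and gives 8700 nM, though it also differs from compound 4 elsewhere. On that thin evidence, a small upward step in this assay is expected, close to the scatter and possibly not beyond it. The estimated step is a 1.5-fold higher number from compound 3 to compound 4 (0.18 log units; within the scatter). For compound 4 the estimated value is 2600 nM, with an expected range of 1100 nM to 6000 nM.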

Compound 4, half-maximal inhibitory concentration: 2730 nM
The estimate for compound 4 lay 1.1-fold (0.02 log units) below the measured number, within the range that was stated.
By their numbers in this assay, from the lowest: compounds 3, 4, 2 and 1 (each within the scatter of the next, the first and the last beyond it).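

In this assay the exchange of 4-(trifluoromethyl)phenyl for 4-bromophenyl on the sulfonyl group gives a 1.6-fold higher number from compound 3 to compound 4 (0.20 log units; within the scatter), so at this position the two groups cannot be told apart. The (4-bromophenyl)sulfonyl group in place of hydrogen on the amine nitrogen in a ring gives a 1.8-fold lower number from compound 2 to compound 4 (0.26 log units; within the scatter), and this step also leaves the two compounds unseparated. Only trifluoromethyl in place of fluoro on an aromatic carbon gives a step that can be read as a real difference, though a modest one, at a 3.2-fold lower number from compound 1 to compound 4 (0.50 log units; beyond the scatter), which makes that aromatic carbon, rather than the group on the sulfonyl or the sulfonyl group itself, the one place in these three steps where this assay separates two compounds.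

As far as these compounds go, it remains open whether a methoxy group, an amine or a carboxylic acid in place of bromo on the sulfonyl-bearing aromatic ring, or a chloro group or a nitrile in place of trifluoromethyl on the other aromatic carbon, would move the number beyond the scatter. Nothing available accounts for the size of any of these steps.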